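The source may hold more compounds than are shown below. What is called first, only, known or untested is meant among the compounds shown, and "the series" means these compounds.

Measured so far in a functional assay on CHO cells for activation of 5-hydroxytryptamine receptor 1D (Homo sapiens), read by GTPgammaS binding; on this read-out lower numbers stand for smaller maximal responses and higher numbers for larger maximal responses:
- compound 1, `CN(Cc1cccs1)C1CCN(CCCc2c[nH]c3ccc(-n4cnnc4)cc23)CC1`: 81%
- compound 2, `c1ccc2c(c1)CCC2NC1CCN(CCCc2c[nH]c3ccc(-n4cnnc4)cc23)CC1`: 68%
- compound 3, `CC(=O)Nc1ccc(CNC2CCN(CCCc3c[nH]c4ccc(-n5cnnc5)cc34)CC2)cc1`: 75%

Compound 2 stands lowest of the three; compound 3 sits close to it, a number 7 percentage points higher from compound 2 to compound 3 (within the scatter), while compound 1 lies further off, as a number 13 percentage points lower from compound 1 to compound 2 (beyond the scatter) shows. Compound 4, `CN(Cc1ccccc1)CC1CCN(CCCc2c[nH]c3ccc(-n4cnnc4)cc23)CC1`, differs from compound 2 in one place: (benzyl(methyl)amino)methyl in place of (2,3-dihydro-1H-inden-1-yl)amino on a saturated ring carbon. For the measured compounds named here, the step that bears on this is the one from compound 1 to compound 2, which changed the group on the same saturated ring carbon and moved the maximal response by a number 13 percentage points lower from compound 1 to compound 2 (beyond the scatter). Compound 4 carries a methylated amine with an aromatic ring, as compound 1 does, so the change is expected to undo part of that loss, a modest rise of a number 9 percentage points higher from compound 2 to compound 4 (within the scatter). Compound 4 is therefore estimated at 77%, within 65% to 89%.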

Compound 4, largest response reached (reported as efficacy), in percent of the reference or control that the assay uses: 93%
Estimate against measurement, compound 4: 16 percentage points below; measured number above the stated range.
By their numbers in this assay, from the lowest: compounds 2, 3 and 1 (each within the scatter of the next, the first and the last beyond it); then compound 4.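

The (benzyl(methyl)amino)methyl group on this saturated ring carbon outdoes both groups it replaces, with a number 25 percentage points higher from compound 2 to compound 4 (beyond the scatter) and a number 12 percentage points higher from compound 1 to compound 4 (beyond the scatter). Compared with (2,3-dihydro-1H-inden-1-yl)amino, it has the same 10 heavy atoms but 0 hydrogen-bond donors and no five-membered ring, so groups of equal atom count can give clearly different maximal responses here. Nothing measured explains this rise. The compounds shown leave open whether the rise would persist with a pyridinylmethyl group on the amine, or with a longer chain carrying that amine.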